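Replacing a Pyridinyl Ring with Methylphenyl on the Shared Core

The source may report more compounds than this note shows. Statements on the series, on what has been measured and on what is new or still open speak of the compounds shown alone.

Three measured compounds share one core and differ only in the aromatic group attached to an aromatic carbon. In an assay on CHO cells for displacement of a labelled ligand from adenosine receptor A1 (Homo sapiens), read by scintillation counting, with a stated time of 3 h (on this read-out lower numbers stand for stronger inhibition and higher numbers for weaker inhibition), compound 1 `Cn1c(-c2cccc(Cl)c2)nc2c(NC3CCCC3)ncnc21` gives 6.5 nM, compound 2 `Cc1ccccc1-c1nc2c(NC3CCCC3)ncnc2n1C` gives 55 nM, and compound 3 `Cn1c(-c2cccnc2)nc2c(NC3CCCC3)ncnc21` gives 242 nM. Compound 3 therefore stands highest of the three, and both steps leading to it lie beyond the scatter: a 37-fold higher number from compound 1 to compound 3 (1.57 log units; beyond the scatter) and a 4.4-fold higher number from compound 2 to compound 3 (0.64 log units; beyond the scatter).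

Compound 4 `Cc1ccc(-c2nc3c(NC4CCCC4)ncnc3n2C)cc1` has not yet been measured. It differs from compound 3 by 4-methylphenyl in place of pyridin-3-yl on an aromatic carbon.

Both measured steps that bear on this change run from an all-carbon ring to pyridin-3-yl, and both raised the number, one by a large and one by a modest amount. The change to compound 4 runs the other way, from pyridin-3-yl to an all-carbon ring, so a lower number in this assay is expected, plausibly landing near the values of compound 1 and compound 2. Compound 4 is thus expected to give about 20 nM, in a range from 5 nM to 80 nM. The expected step is a 12-fold lower number from compound 3 to compound 4 (1.08 log units; beyond the scatter).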

Compound 4, inhibition constant: 8 nM
Compound 4: the middle estimate sits 2.5-fold (0.40 log units) above what was measured; the range from low to high includes it.
By their numbers in this assay, from the lowest: compounds 1 and 4 (each within the scatter of the next); then compound 2; then compound 3.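

In this assay, the change from pyridin-3-yl to an all-carbon ring can now be read directly at this aromatic carbon, and the effect is large: a 30-fold lower number from compound 3 to compound 4 (1.48 log units; beyond the scatter). Where the methyl group sits on the phenyl ring also matters, since moving from 2-methylphenyl to 4-methylphenyl gives a 6.9-fold lower number from compound 2 to compound 4 (0.84 log units; beyond the scatter), so these two methylphenyl groups are not interchangeable here. By contrast, 4-methylphenyl and 3-chlorophenyl cannot be told apart in this assay, with a 1.2-fold higher number from compound 1 to compound 4 (0.09 log units; within the scatter).

The data shown offer no measured explanation for any of these differences. Going by these compounds, it also remains open whether a phenyl ring carrying an amine or a carboxylic acid, rather than a methyl group or chlorine, would keep the number as low as that of compound 4.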